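The source may report more compounds than this note shows. Statements on the series, on what has been measured and on what is new or still open speak of the compounds shown alone.

Measured so far:
compound 1 `Brc1ccc(-c2nnc(SCCCN3CCN(c4nc5ccccc5o4)CC3)o2)cc1`: 123000 nM
compound 2 `O=[N+]([O-])c1ccc(-c2nnc(SCCCN3CCN(c4nc5ccccc5s4)CC3)o2)cc1`: 96600 nM
compound 3 `Clc1ccc(-c2nnc(SCCCN3CCN(c4nc5ccccc5s4)CC3)o2)cc1`: 110000 nM

In a functional assay on A549 cells (Homo sapiens) for inhibition, read by MTT assay, with a stated time of 72 h (a lower number here means a stronger inhibitor, a higher number a weaker inhibitor), compound 3 gives 110000 nM, within the scatter of both other compounds, so the three values set no order. Compound 4 `Brc1ccc(-c2nnc(SCCCN3CCN(c4nc5ccccc5s4)CC3)o2)cc1` differs from compound 3 by one substituent: bromo in place of chloro on an aromatic carbon. This is bromo in place of chloro on an aromatic carbon, 4-chlorophenyl to 4-bromophenyl. Going by the values given here, one measured step bears on it, the change at that same place, a 1.1-fold higher number from compound 2 to compound 3 (0.06 log units; within the scatter). Even the swap of nitro for chloro stayed within the scatter, so no step beyond the scatter is expected in this assay, and no direction. The expected step is no change at the digits printed from compound 3 to compound 4 (within the scatter). The estimate for compound 4 is 110000 nM, with an expected range of 70000 nM to 170000 nM.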

Compound 4, half-maximal inhibitory concentration: 62500 nM
For compound 4 the middle estimate is 1.8-fold (0.25 log units) above the measured one, outside the stated range (below it).
By their numbers in this assay, from the lowest: compounds 4, 2, 3 and 1 (each within the scatter of the next).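

In this assay, bromo in place of chloro gives a 1.8-fold lower number from compound 3 to compound 4 (0.25 log units; within the scatter), and bromo in place of nitro gives a 1.5-fold lower number from compound 2 to compound 4 (0.19 log units; within the scatter), so the three substituents at this position on the aromatic ring remain unseparated. A second place can now be read: 1,3-benzothiazol-2-yl in place of 1,3-benzoxazol-2-yl on an amine nitrogen in a ring gives a 2.0-fold lower number from compound 1 to compound 4 (0.29 log units; within the scatter), which also sets no order. No supporting measurement bears on these steps. From the compounds shown here alone, whether an amine or a carboxylic acid at this position would give a step beyond the scatter remains open.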